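Compound 3: 2-bromophenyl in place of 4-fluorophenyl

This account rests on a few compounds, and the source may have more. Where it says the series, first, only, none or still open, it means among the compounds named here.

Compound 1 `Cc1ccccc1Cn1ccc2nc(-c3ccccc3)nc-2c1` gives > 100000 nM (a limit)
Compound 2 `Fc1ccc(Cn2ccc3nc(-c4ccccc4)nc-3c2)cc1` gives > 100000 nM (a limit)

In an ADME assay on MDBK cells (Bos taurus) for cytotoxicity (a higher number here means that more compound is tolerated, a lower number that less compound is tolerated), compound 2 stands at > 100000 nM as a limit and not a number. Compound 1 likewise gives > 100000 nM as a limit. Together they offer the limit of > 100000 nM in this assay, at which 2 of the 2 values shown sit, as the only evidence. Compound 3 `Brc1ccccc1Cn1ccc2nc(-c3ccccc3)nc-2c1` carries 2-bromophenyl in place of 4-fluorophenyl on a saturated chain carbon bound to an aromatic nitrogen. Within the data shown here, the only measured step is a step that the two limits leave unreadable from compound 1 to compound 2 and it offers no size to carry over. The estimated step in this assay is a number no higher from compound 2 to compound 3 (the limit leaves the size open) and none beyond the scatter is expected. Compound 3 is expected at 100000 nM (estimated range 40000 nM to 100000 nM).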

Compound 3, half-maximal cytotoxic concentration: > 100000 nM
Compound 3: no number, only a limit (the forecaster's own chance of this, stated with the estimate: 80%); the middle value sits exactly at the limit.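

In this assay compound 3 gives only a limit, as compound 1 and compound 2 do, so no step among these three compounds can be read. Whether these groups change tolerance at all stays open: the limit of > 100000 nM in this assay, at which 3 of the 3 values shown sit.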